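This account rests on a few compounds, and the source may have more. Where it says the series, first, only, none or still open, it means among the compounds named here.

Compound 2 `CN(c1ccc2[nH]c(-c3n[nH]c4ccccc34)cc2n1)S(=O)(=O)c1ccc(Cl)cc1` carries a (4-chlorophenyl)sulfonyl group on the ring nitrogen of the shared core. For the measured compounds named here, in a functional assay on SMMC-7721 cells (Homo sapiens) for antiproliferative activity, read by MTT assay, with a stated time of 72 h (a lower number here means a stronger inhibitor, a higher number a weaker inhibitor), compound 2 gives 12700 nM, the highest of the two numbers known; its nearest neighbour, compound 1 `CN(C(=O)c1ccc(Br)cc1)c1ccc2[nH]c(-c3n[nH]c4ccccc34)cc2n1`, which bears a (4-bromophenyl)carbonyl group at the same nitrogen, gives 3460 nM, and the step of a 3.7-fold higher number from compound 1 to compound 2 (0.56 log units; beyond the scatter) lies beyond the scatter. Compound 3 `COc1ccc(S(=O)(=O)N(C)c2ccc3[nH]c(-c4n[nH]c5ccccc45)cc3n2)cc1` differs from compound 2 in one place: methoxy in place of chloro on an aromatic carbon. Going by the values given here, no measured pair shows what a change at this position of the aryl ring does; the one step known, from compound 1 to compound 2, alters the link to the nitrogen and is of no direct help here. Compound 3 is therefore expected to remain close to compound 2 in this assay, with a step of about a 1.1-fold lower number from compound 2 to compound 3 (0.02 log units; within the scatter) that need not exceed the scatter. The estimate for compound 3 is 12000 nM, between 5000 nM and 30000 nM.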

Compound 3, half-maximal inhibitory concentration: 13000 nM
Compound 3: the middle estimate sits 1.1-fold (0.03 log units) below what was measured; measured number inside the range.
By their numbers in this assay, from the lowest: compound 1; then compounds 2 and 3 (each within the scatter of the next).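

For the compounds shown here, the change from 4-chlorophenyl to 4-methoxyphenyl gives the first reading of what this position of the aryl ring tolerates: in this assay the step is a 1.0-fold higher number from compound 2 to compound 3 (0.01 log units; within the scatter), so the two compounds cannot be told apart. Methoxy brings a hydrogen-bond acceptor that chloro lacks, yet in this pair that exchange leaves the number within the scatter. The material at hand offers no measurement that would account for this result.

Going by these compounds, the comparison covers only these two groups, both on the sulfonyl link, so it remains open whether an amine or a carboxylic acid on the same aromatic carbon would behave alike. On these data alone, it is also open whether the same exchange would be equally silent on the carbonyl link of compound 1.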